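One added methyl, from compound 2 to compound 3

The source may report more compounds than this note shows. Statements on the series, on what has been measured and on what is new or still open speak of the compounds shown alone.

Values measured in a functional assay (aorta) with Oryctolagus cuniculus as the target (a higher number here means weaker binding, a lower number tighter binding), are these
- Compound 1 `CCCc1nc2c(C)ccnc2n1Cc1ccc(-c2ccccc2C(=O)O)cc1` gives 3.16 nM; 3.16 nM (2 entries)
- Compound 2 `Cc1ccnc2c1nc(C)n2Cc1ccc(-c2ccccc2C(=O)O)cc1` gives 50.1 nM

Of the two numbers available in this assay, compound 2 stands at the higher one (50.1 nM), which means weaker binding than compound 1 shows (3.16 nM; 3.16 nM (2 entries)). One further entry for compound 2 carries no single number. Compound 3 `CCc1nc2c(C)ccnc2n1Cc1ccc(-c2ccccc2C(=O)O)cc1` has not yet been measured. It departs from compound 2 by one change (methyl in place of hydrogen on a saturated chain carbon bound to an aromatic carbon), methyl in place of hydrogen on a saturated chain carbon bound to an aromatic carbon, which turns methyl into ethyl. Among the compounds with values here, no measured single-place step is available as a guide. The expectation therefore rests on the gap to compound 1, which gives 3.16 nM; 3.16 nM (2 entries), and points to a step beyond the scatter, towards tighter binding. The expected change is a 6.3-fold lower number from compound 2 to compound 3 (0.80 log units; beyond the scatter), an estimate only. For compound 3 the estimated value is 8 nM, with an expected range from 3 nM to 25 nM.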

Compound 3, dissociation constant: 1.26 nM
Compound 3: the middle estimate sits 6.3-fold (0.80 log units) above what was measured; the whole stated range lies above it.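

In this assay, one added methyl on the saturated chain carbon bound to an aromatic carbon, turning methyl into ethyl, brings a 40-fold lower number from compound 2 to compound 3 (1.60 log units; beyond the scatter), so this place responds strongly to a very small change. The earlier compounds shown here showed only the gap between compound 2 and the longer chain of compound 1, whereas a single added carbon now proves enough, with compound 3 at 1.26 nM and compound 1 at 3.16 nM; 3.16 nM (2 entries). No available measurement accounts for this response.

On these data alone, it remains open whether a branched chain such as isopropyl, or a chain carrying an oxygen such as methoxymethyl, would keep the number this low at this place. With only methyl, ethyl and propyl shown, the effect of a longer chain such as butyl also remains unknown.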